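A few compounds are considered here, and "the series" means these few. Any claim that something is new, unique, unknown or untested is made for them only; others in the source may bear on it.

Measured so far:
compound 1 `Cc1nc2c(Oc3ccccc3)cccn2c1N` — 34%
compound 2 `Cc1nc2c(OCc3ccccc3)cccn2c1NC=O` — 49%

Among the compounds with values here, in a functional assay on the whole organism with Rattus norvegicus as the target, at a dose of 40 mg/kg by the intraperitoneal route (on this read-out lower numbers stand for less inhibition and higher numbers for more inhibition at the one dose given (going by the name of the read-out)), compound 2 gives 49%, the higher of the two numbers known, while compound 1 gives 34%, a gap beyond the scatter. The two structures differ in more than one place, so the gap is noted without a single change to account for it. Compound 3 `Cc1nc2c(OCc3ccccc3)cccn2c1NC(=O)OCc1ccccc1` has not yet been measured in this assay. It differs from compound 2 by benzyloxy in place of hydrogen on a carbonyl carbon. Within the data shown here, no measured pair shows this change, so nothing anchors its size; the step expected is a number 4 percentage points lower from compound 2 to compound 3 (within the scatter), a change within the scatter in either direction. Compound 3 is expected to give about 45%, within 25% to 65%.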

Compound 3, a percentage reported as inhibition, in the whole organism at one dose (the size of the read-out at that dose, not a potency): 8%
Compound 3: the middle estimate sits 37 percentage points above what was measured, and the stated range ends above it.
By their numbers in this assay, from the lowest: compound 3; then compound 1; then compound 2.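

In this assay the carbonyl carbon on the amide-type nitrogen proves sensitive to substitution: with benzyloxy in place of hydrogen, the read-out moves a number 41 percentage points lower from compound 2 to compound 3 (beyond the scatter) and this large step goes toward less inhibition. Within the data shown here, this is the first change confined to one place, so it gives the position its first measured step. Nothing available explains the loss.

As far as these compounds go, whether the loss follows the aromatic ring of benzyloxy or its oxygen stays open. Methoxy or phenyl on the same carbonyl carbon would separate the two.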